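The source may report more compounds than this note shows. Statements on the series, on what has been measured and on what is new or still open speak of the compounds shown alone.

Compound 1: `C/C(=C\CC/C(C)=C/CC[C@@H]1[C@@]2(C)CCC(=O)C(C)(C)[C@H]2CC[C@@]1(C)O)CC/C=C(\C)C(=O)OCc1cn(-c2ccccc2Br)nn1` — > 150000 nM
Compound 2: `C/C(=C\CC/C(C)=C/CC[C@@H]1[C@@]2(C)CCC(=O)C(C)(C)[C@H]2CC[C@@]1(C)O)CC/C=C(\C)C(=O)OCc1cn(C[C@@H]2O[C@H](n3ccc(=O)[nH]c3=O)C[C@H]2O)nn1` — 148000 nM

In an ADME assay on L132 cells (Homo sapiens) for cytotoxicity, read by MTT assay, with a stated time of 48 h (a lower number here means a stronger inhibitor, a higher number a weaker inhibitor), compound 1 is reported only as a limit, > 150000 nM. Compound 2 gives 148000 nM in this assay, a number near that edge. The two values show both compounds as weak inhibitors of these cells, and nothing separates them beyond the usual scatter, since one of them is a limit rather than a number (the limit of > 150000 nM in this assay, at which 1 of the 2 values shown sits).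

Compound 3, `C/C(=C\CC/C(C)=C/CC[C@@H]1[C@@]2(C)CCC(=O)C(C)(C)[C@H]2CC[C@@]1(C)O)CC/C=C(\C)C(=O)OCc1cn(-c2ccccc2Cl)nn1`, has not yet been measured in this assay. It differs from compound 1 in one place: chloro in place of bromo on an aromatic carbon. Within the data shown here, no step between measured compounds describes this kind of exchange, so the expectation for compound 3 rests on where compound 1 stands. The step from compound 1 to compound 3 in this assay is expected to be small, with no direction beyond the scatter a number no higher from compound 1 to compound 3 (the limit leaves the size open). Compound 3 is therefore estimated at 150000 nM, within a range from 80000 nM to 300000 nM, and it may again be reported only as a limit.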

Compound 3, half-maximal inhibitory concentration: > 150000 nM
Compound 3 ended at the assay's limit (the forecaster's own chance of this, stated with the estimate: 60%); the middle value sits exactly at the limit.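

In this assay compound 3 is reported only as a limit, > 150000 nM, so no step from compound 1 to compound 3 can be read for chloro in place of bromo: the limit of > 150000 nM in this assay, at which 2 of the 3 values shown sit.

The compounds shown leave open whether compound 1 and compound 3 differ at all in this assay.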